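The compounds below may be only part of what the source reports. "The series", "measured", "known", "first", "only" and "open" are said of these compounds alone.

Measured in a functional assay on MDA-MB-231 cells (Homo sapiens) for antiproliferative activity, with a stated time of 4 days; a lower number here means a stronger inhibitor, a higher number a weaker inhibitor:
compound 1 `COc1ccc(-c2[nH]c3ccc(F)cc3c2C=O)cc1`: 540 nM
compound 2 `COc1ccc(-c2[nH]c3ccc(C)cc3c2C=O)cc1`: 86 nM
compound 3 `COc1ccc(-c2[nH]c3ccc(C(C)C)cc3c2C=O)cc1`: 29 nM

Compound 2, at 86 nM, holds the middle of the three values. It lies below compound 1 and above compound 3, as shown by the steps of a 6.3-fold lower number from compound 1 to compound 2 (0.80 log units; beyond the scatter) and a 3.0-fold lower number from compound 2 to compound 3 (0.47 log units; beyond the scatter).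

Compound 4 `Cc1ccc(-c2[nH]c3ccc(C)cc3c2C=O)cc1` keeps the methyl of compound 2 but carries methyl in place of methoxy on an aromatic carbon, para to a large group (methyl in place of methoxy on an aromatic carbon). For the measured compounds named here, all three measured compounds keep the methoxy, so no measured step tests this change directly. The steps show only how far a single swap can move the number on this core, from a 3.0-fold lower number from compound 2 to compound 3 (0.47 log units; beyond the scatter) up to a 19-fold lower number from compound 1 to compound 3 (1.27 log units; beyond the scatter). The direction therefore remains a judgement, and a modest move to a higher number in this assay is expected. The expected change is a 2.3-fold higher number from compound 2 to compound 4 (0.37 log units; beyond the scatter). The estimate for compound 4 is 200 nM, with an expected range of 70 nM to 600 nM.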

Compound 4, half-maximal inhibitory concentration: 48 nM
Estimate against measurement, compound 4: 4.2-fold (0.62 log units) above; the whole stated range lies above it.
By their numbers in this assay, from the lowest: compounds 3, 4 and 2 (each within the scatter of the next, the first and the last beyond it); then compound 1.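

In this assay, methyl in place of methoxy on an aromatic carbon, para to a large group, gives a 1.8-fold lower number from compound 2 to compound 4 (0.25 log units; within the scatter). For the compounds shown here, compound 1, compound 2 and compound 3 all keep the methoxy, so this is the first reading at this position, and in this one pair the loss of the methoxy oxygen and its hydrogen-bond acceptor leaves no change that the assay can separate from scatter. Why the two compounds read alike cannot be said, as no supporting measurement bears on this result.

From the compounds shown here alone, whether this position also accepts an amine, a carboxylic acid or a longer chain stays open. Going by these compounds, it is also open whether the same swap would read the same way on the core of compound 1 or compound 3, with fluoro or isopropyl in place of the methyl kept here.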